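The compounds below may be only part of what the source reports. "The series", "measured", "known", "first", "only" and "open" are said of these compounds alone.

Of the compounds shown here, three built on one shared core have so far been tested in a functional assay on HepG2 cells (Homo sapiens) for cytotoxicity, read by MTT assay, with a stated time of 48 h; on this read-out higher numbers stand for weaker inhibition and lower numbers for stronger inhibition. Compound 1 `CC(=O)c1c(O)ccc2oc(-c3ccccc3C)nc12` gives 11700 nM. Compound 2 `O=Cc1c(O)ccc2oc(-c3ccccc3Cl)nc12` gives 10500 nM. Compound 3 `Cc1ccccc1-c1nc2c(C=O)c(O)ccc2o1` gives 4740 nM, the lowest of the three numbers: the step of a 2.5-fold lower number from compound 1 to compound 3 (0.39 log units; beyond the scatter) and the step of a 2.2-fold lower number from compound 2 to compound 3 (0.35 log units; beyond the scatter) both lie beyond the scatter, so compound 3 stands as the strongest of the measured set. Compound 4 `COc1ccccc1-c1nc2c(C=O)c(O)ccc2o1` has not yet been measured. It differs from compound 3 in one place: methoxy in place of methyl on an aromatic carbon. Of the measured steps, only a 2.2-fold lower number from compound 2 to compound 3 (0.35 log units; beyond the scatter) changed the group at that same place, and it was modest; a 2.5-fold lower number from compound 1 to compound 3 (0.39 log units; beyond the scatter) altered a different part of the molecule and says nothing about a methoxy here. Within the data shown here, no measured pair sets methyl against methoxy, so the direction is open. The expectation is a step of about a 1.2-fold higher number from compound 3 to compound 4 (0.06 log units; within the scatter), within the scatter. Compound 4 is therefore estimated to give about 5500 nM, in a range from 2500 nM to 12000 nM.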

Compound 4, half-maximal inhibitory concentration: 10800 nM
The estimate for compound 4 lay 2.0-fold (0.29 log units) below the measured number; the measured number falls inside the stated range.
By their numbers in this assay, from the lowest: compound 3; then compounds 2, 4 and 1 (each within the scatter of the next).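

In this assay the change from methyl to methoxy on this aromatic carbon, ortho to a large group, gives a 2.3-fold higher number from compound 3 to compound 4 (0.36 log units; beyond the scatter) and so shows that this swap weakens inhibition modestly in this pair. Methoxy and chloro cannot be told apart at this place, with a 1.0-fold higher number from compound 2 to compound 4 (0.01 log units; within the scatter) as their step, so methyl is the only one of these three groups that stands clear of the other two, and it gives the lowest number. Nothing available explains why methyl differs from the other two groups here.

From the compounds shown here alone, whether an amine, a hydroxyl or a longer chain such as ethyl at this place would give a number lower than that of compound 3 remains open. Going by these compounds, it is also open whether methyl would keep its lead over methoxy and chloro on the core of compound 1.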